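Fluorine on the Phenyl Ring of an Inactive Series

The source may hold more compounds than are shown below. What is called first, only, known or untested is meant among the compounds shown, and "the series" means these compounds.

Of the compounds shown here, three built on one shared core have been measured in a functional assay on HCT-116 cells (Homo sapiens) for antiproliferative activity, read by MTT assay, with a stated time of 24 h; on this read-out lower numbers stand for stronger inhibition and higher numbers for weaker inhibition. Compound 1 `c1ccc(-c2noc(-c3ccncc3)n2)cc1` carries a pyridine on one side of the core. In this assay compound 1 gives > 1000000 nM, which is a limit of the assay rather than a number. Compound 2 `COc1ccc(-c2noc(-c3ccccc3)n2)cc1OC1CCCC1` replaces the pyridine with a phenyl and adds a methoxy and a cyclopentyloxy group. Compound 2 gives > 1000000 nM, again only a limit. Compound 3 `COc1ccc(-c2noc(-c3ccc(Cl)cc3)n2)cc1OC1CCCC1` adds a chloro to the phenyl of compound 2, and compound 3 gives > 1000000 nM, also a limit. Within the data shown here, the one step that can be compared, a step that the two limits leave unreadable from compound 2 to compound 3, is therefore unreadable; both ends rest on the same boundary, as the limit of > 1000000 nM in this assay, at which 3 of the 3 values shown sit, shows, so no size or direction can be drawn from it.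

Compound 4 `COc1ccc(-c2noc(-c3ccc(F)cc3)n2)cc1OC1CCCC1` has not yet been measured. Its difference from compound 2 is fluoro in place of hydrogen on an aromatic carbon, the same difference, cut one bond further out, reading phenyl to 4-fluorophenyl. Among the measured compounds shown here, the only step that bears on it is the unreadable one from compound 2 to compound 3, which gives no guidance in either direction. Compound 4 is therefore expected to sit at the same boundary, with an estimated step of a number no higher from compound 2 to compound 4 (the limit leaves the size open). For compound 4 the expected value is 1000000 nM, within an estimated range from 200000 nM to 5000000 nM.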

Compound 4, half-maximal inhibitory concentration: 210000 nM
Compound 4: middle estimate off by 4.8-fold (0.68 log units), on the high side; the range from low to high includes it.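

Compound 4 alone among the four gives a number rather than a limit in this assay, which shows that this series can register activity in the assay and that this position, on an aromatic carbon para to a large group, can change the result. Placing fluoro there in place of hydrogen gives an at least 4.7-fold lower number from compound 2 to compound 4 (0.67 log units; beyond the scatter). Placing fluoro in place of chloro at the same carbon gives an at least 4.7-fold lower number from compound 3 to compound 4 (0.67 log units; beyond the scatter), so on this position the two halogens do not give the same result, which compound 3 alone could not reveal.

Both steps give only a minimum size and their true size stays open, because compound 2 and compound 3 rest on a boundary and not on numbers: the limit of > 1000000 nM in this assay, at which 3 of the 4 values shown sit.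

Also open, on these data alone, is how a nitrile, an amine or a carboxylic acid at this same position would compare with fluoro, and whether fluoro would produce a similar change on a different aromatic carbon of the molecule.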